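The compounds below may be only part of what the source reports. "The series", "measured", "known", "first", "only" and "open" are said of these compounds alone.

- compound 1 `O=S(=O)(/C=C/c1ccc(C(F)(F)F)cc1F)Cc1ccc(Nc2ncnc3ccccc23)cc1` gives 100000 nM in a functional assay on NCI-H520 cells (Homo sapiens); a higher number here means a weaker inhibitor of growth, a lower number a stronger inhibitor of growth
- compound 2 `O=S(=O)(/C=C/c1ccc(Br)cc1)Cc1ccc(Nc2ncnc3ccc(Br)cc23)cc1` gives 20000 nM in this assay
- compound 3 `O=S(=O)(/C=C/c1ccc(Cl)cc1Cl)Cc1ccc(Nc2ncnc3ccc(Br)cc23)cc1` gives 8000 nM in this assay

Compound 3 has the lowest number of the three, with compound 2 nearest at 20000 nM and compound 1 furthest at 100000 nM on the high side. The move to compound 4 `O=S(=O)(/C=C/c1ccc(C(F)(F)F)cc1F)Cc1ccc(Nc2ncnc3ccc(Br)cc23)cc1` brings 2-fluoro-4-(trifluoromethyl)phenyl in place of 2,4-dichlorophenyl on a double-bonded chain carbon bound to a double-bonded chain carbon with 2-fluoro-4-(trifluoromethyl)phenyl in place of 2,4-dichlorophenyl on a double-bonded chain carbon bound to a double-bonded chain carbon. Within the data shown here, the only measured change at that place is a 2.5-fold lower number from compound 2 to compound 3 (0.40 log units; beyond the scatter) and its size is modest. Among the measured compounds shown here, compound 1 carries the entering group on a different core and stands at 100000 nM in the same assay, but no measured pair isolates that group. From the modest size of the step to compound 3 and the high value of compound 1, a modest rise is expected in this assay and not a large one. The estimated change is a 1.8-fold higher number from compound 3 to compound 4 (0.24 log units; within the scatter) with wide uncertainty. Compound 4 is estimated at 14000 nM with an expected range from 5000 nM to 45000 nM in this estimate.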

Compound 4, concentration for 50% growth inhibition: 40000 nM
Compound 4: the middle estimate sits 2.9-fold (0.46 log units) below what was measured; the measured number falls inside the stated range.
By their numbers in this assay, from the lowest: compound 3; then compounds 2 and 4 (each within the scatter of the next); then compound 1.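

In this assay, 2-fluoro-4-(trifluoromethyl)phenyl in place of 2,4-dichlorophenyl on a double-bonded chain carbon gives a 5.0-fold higher number from compound 3 to compound 4 (0.70 log units; beyond the scatter), which shows that this position also responds to a change between two substituted phenyl groups. Set against 4-bromophenyl, the same group gives a 2.0-fold higher number from compound 2 to compound 4 (0.30 log units; within the scatter), so among these three groups on the shared core only 2,4-dichlorophenyl stands apart. Among these compounds, with the entering group held fixed, bromo in place of hydrogen on an aromatic carbon gives a 2.5-fold lower number from compound 1 to compound 4 (0.40 log units; beyond the scatter), a core effect that no earlier pair could isolate.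

Nothing available here explains why these groups differ. On these data alone, it remains open how a phenyl group carrying an amine or a carboxylic acid would compare at this position, and whether bromo on the core gives a similar step with 2,4-dichlorophenyl in place.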